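This account rests on a few compounds, and the source may have more. Where it says the series, first, only, none or still open, it means among the compounds named here.

Of the compounds shown here, three have so far been measured in an assay on HEK293 cells for positive allosteric modulation of metabotropic glutamate receptor 3 (Rattus norvegicus), read by thallium flux, with a stated time of 2.5 min; a higher number here means a larger maximal response, a lower number a smaller maximal response. Compound 1 `Cc1c(OCCCCOc2ccc(C(=O)C(C)C)c(O)c2C)cccc1C(=O)O` gives 27.1%. Compound 2 `CCC(=O)c1ccc(OCCCCOc2cc(C(=O)O)ccc2OC)c(C)c1O` gives 62.5%, and compound 3 `CCCC(=O)c1ccc(OCCCCOc2cc(C(=O)O)ccc2OC)c(C)c1O` gives 64.2%. Compound 1 stands lowest of the three; how its core differs from that of compound 3 is not broken down here. Compounds 3 and 2 differ in one place, (hydrogen in place of methyl on a saturated chain carbon, two bonds along the chain from a carbonyl carbon), and that step was a number 1.7 percentage points lower from compound 3 to compound 2 (within the scatter). Compound 4 `CCC(=O)c1ccc(OCCCCOc2cccc(C(=O)O)c2C)c(C)c1O` has not been measured; it differs from compound 1 by hydrogen in place of methyl on a saturated chain carbon bound to a carbonyl carbon and a saturated chain carbon. This is the same kind of change, though not at the same place: in compound 2 the carbon is two bonds along the chain from a carbonyl carbon, in compound 4 it is bound to a carbonyl carbon and a saturated chain carbon. Because the earlier step of a number 1.7 percentage points lower from compound 3 to compound 2 (within the scatter) stayed within the scatter, a similarly small step is expected, a number 1.1 percentage points lower from compound 1 to compound 4 (within the scatter). Compound 4 is therefore estimated at 26%, between 14% and 38%.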

Compound 4, largest response reached (reported as percent of maximum), in percent of the reference or control that the assay uses: 16.3%
For compound 4 the middle estimate is 9.7 percentage points above the measured one, within the range that was stated.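

In this assay, trimming isopropyl to ethyl, that is, putting hydrogen in place of methyl on the saturated chain carbon bound to a carbonyl carbon, gave a number 10.8 percentage points lower from compound 1 to compound 4 (beyond the scatter). Set beside the earlier step, the two cores do not clearly respond differently to this kind of change: the same change on two cores in this assay, a number 1.7 percentage points lower (within the scatter) from compound 3 to compound 2 and a number 10.8 percentage points lower (beyond the scatter) from compound 1 to compound 4, 9.1 percentage points apart, within the scatter of two such steps This does not show that the change carries over equally: only two pairs are shown, the altered carbon sits at a different place in each, and a real dependence on the core remains possible.

All the compounds shown carry a carboxylic acid and the same linking chain. From the compounds shown here alone, how an amide in place of that acid, or a longer linking chain, would read in this assay stays open.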